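The source may hold more compounds than are shown below. What is called first, only, known or untested is meant among the compounds shown, and "the series" means these compounds.

Compound 1 `COC(=O)NCC1Cc2ccc(NC(=O)c3cccc(C)c3-c3ccc(C(F)(F)F)cc3)cc2C1`: 24 nM
Compound 2 `COC(=O)NCC1Cc2ccc(NC(=O)c3cc(C)cc(C)c3-c3ccc(C(F)(F)F)cc3)cc2C1`: 40 nM

In an assay on isolated protein for inhibition of microsomal triglyceride transfer protein large subunit (Homo sapiens) (a higher number here means a weaker inhibitor, a lower number a stronger inhibitor), compound 1 gives the lowest of the two numbers; the only other, compound 2, sits a 1.7-fold higher number from compound 1 to compound 2 (0.22 log units; within the scatter) away, a gap too small to call a real change. Compound 3 `COC(=O)NCCC1Cc2ccc(NC(=O)c3cccc(C)c3-c3ccc(C(F)(F)F)cc3)cc2C1` differs from compound 1 by ((methoxycarbonyl)amino)methyl in place of (methoxycarbonyl)amino on a saturated chain carbon bound to a saturated ring carbon. For the measured compounds named here, the one measured step, a 1.7-fold higher number from compound 1 to compound 2 (0.22 log units; within the scatter), concerns a methyl on an aromatic carbon and says nothing about lengthening this chain, so no step beyond the scatter is expected. Compound 3 is therefore estimated at 30 nM, plausibly between 10 nM and 90 nM, meaning an expected 1.3-fold higher number from compound 1 to compound 3 (0.10 log units; within the scatter).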

Compound 3, half-maximal inhibitory concentration: 70 nM
Compound 3: middle estimate off by 2.3-fold (0.37 log units), on the low side; measured number inside the range.
By their numbers in this assay, from the lowest: compounds 1, 2 and 3 (each within the scatter of the next, the first and the last beyond it).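

In this assay the length of this chain matters: going from ((methoxycarbonyl)amino)methyl to 2-((methoxycarbonyl)amino)ethyl gives a modest loss (a 2.9-fold higher number from compound 1 to compound 3 (0.46 log units; beyond the scatter)). This is the first change among these compounds that lies beyond the scatter, so small edits to this chain can be read in this assay. Nothing at hand explains the loss. Going by these compounds, whether a longer chain, such as 3-((methoxycarbonyl)amino)propyl, would raise the number further stays open. So does the effect of a plain amine at the chain end.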